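Chain-terminus variation in the allylacetophenone series

The source may report more compounds than this note shows. Statements on the series, on what has been measured and on what is new or still open speak of the compounds shown alone.

Measured so far:
compound 1 `C=CCc1cc(C(C)=O)c(O)cc1OCC#N` gives 20% in an assay on isolated protein for inhibition of leukotriene B4 receptor 1 (Homo sapiens), tested at 10 uM; a higher number here means more inhibition at the concentration tested (going by the name of the read-out), a lower number less inhibition
compound 2 `C=CCc1cc(C(C)=O)c(O)cc1OCCCC#N` gives 47% in this assay
compound 3 `C=CCc1cc(C(C)=O)c(O)cc1OCCCCCCC` gives 31% in this assay

Compound 3 stands second highest of the three numbers: above compound 1 by a number 11 percentage points higher from compound 1 to compound 3 (beyond the scatter) and below compound 2, the step being a number 16 percentage points lower from compound 2 to compound 3 (beyond the scatter). Compound 4 `C=CCc1cc(C(C)=O)c(O)cc1OCCCCCC(=O)NO` is the next member; it differs from compound 3 in one place: hydroxycarbamoyl in place of ethyl on a saturated chain carbon, five bonds along the chain from an oxygen on an aromatic ring.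

Going by the values given here, the steps that bear on this are those that exchange an alkyl terminus for a nitrile terminus. a number 16 percentage points lower from compound 2 to compound 3 (beyond the scatter) shows the alkyl chain of compound 3 behind the nitrile chain of compound 2, and a number 27 percentage points higher from compound 1 to compound 2 (beyond the scatter) shows that carrying a nitrile further out along the chain raised the number. Among the compounds with values here, no measured step involves a hydroxycarbamoyl group, so the size of its effect is unknown. On the two steps above, a modest rise is expected for compound 4, a number 11 percentage points higher from compound 3 to compound 4 (beyond the scatter). Compound 4 is therefore estimated at 42%, within 18% to 66%.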

Compound 4, a percentage reported as inhibition, at one concentration (the size of the read-out at that concentration, not a potency): 85%
The estimate for compound 4 lay 43 percentage points below the measured number; measured number outside the range, above it.
By their numbers in this assay, from the lowest: compound 1; then compound 3; then compound 2; then compound 4.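

Going by these compounds alone, at this chain end, the identity of the terminal group carries far more weight than the alkyl and nitrile variation had indicated: hydroxycarbamoyl in place of ethyl gives a number 54 percentage points higher from compound 3 to compound 4 (beyond the scatter) in this assay, the largest step so far. The gain also holds against a nitrile terminus, with 2-(hydroxycarbamoyl)ethyl in place of cyano giving a number 38 percentage points higher from compound 2 to compound 4 (beyond the scatter), so the higher number is not reached by the nitrile-ended chain of compound 2. No supporting data are available to account for this gain.

Open, going by these compounds, is whether the rise depends on the hydroxycarbamoyl group itself or would also appear with a carboxylic acid, a primary amide or a methyl ester on the same chain. Also open, on these data alone, is how the number changes when hydroxycarbamoyl sits on a shorter or a longer chain.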